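Aryl swap on the benzylidene arm: compound 2 to compound 3

This account rests on a few compounds, and the source may have more. Where it says the series, first, only, none or still open, it means among the compounds named here.

Going by the values given here, compound 2 `C=CCn1c(=O)/c(=C\c2cccc(C)c2)[nH]c(=O)/c1=C\c1ccccc1OC` gives the highest of the two numbers so far in a functional assay on HeLa cells (Homo sapiens) for cytotoxicity, read by CCK-8 assay, with a stated time of 72 h (a lower number here means a stronger inhibitor, a higher number a weaker inhibitor), with compound 2 at 19300 nM. Its nearest neighbour, compound 1 `C=CCn1c(=O)/c(=C\c2cc(F)ccc2C)[nH]c(=O)/c1=C\c1ccccc1OC`, gives 2900 nM in this assay. Among the compounds with values here, the one relevant step, a 6.7-fold higher number from compound 1 to compound 2 (0.82 log units; beyond the scatter), shows that the aryl group on this arm matters beyond the scatter. Compound 3 `C=CCn1c(=O)/c(=C\c2ccccc2F)[nH]c(=O)/c1=C\c1ccccc1OC` is the next variation: 2-fluorophenyl in place of 3-methylphenyl on a double-bonded chain carbon bound to an aromatic carbon. Within the data shown here, compound 3 shares a fluorine with compound 1 but lacks the methyl that both measured compounds carry on this ring, so the single step available bears on it only loosely. The expectation is that compound 3 lands between compound 1 and compound 2, estimated as a 2.8-fold lower number from compound 2 to compound 3 (0.44 log units; beyond the scatter) from compound 2. Compound 3 is therefore expected to give about 7000 nM in this assay, with a range from 2500 nM to 20000 nM.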

Compound 3, half-maximal inhibitory concentration: 45000 nM
For compound 3 the middle estimate is 6.4-fold (0.81 log units) below the measured one; measured number above the stated range.
By their numbers in this assay, from the lowest: compound 1; then compound 2; then compound 3.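

In this assay setting 2-fluorophenyl in place of 3-methylphenyl gives a 2.3-fold higher number from compound 2 to compound 3 (0.37 log units; beyond the scatter) and setting it in place of 5-fluoro-2-methylphenyl gives a 16-fold higher number from compound 1 to compound 3 (1.19 log units; beyond the scatter) on the same arm. A fluorine on this ring therefore does not by itself bring the low number of compound 1: compound 3 also carries fluorine yet gives the highest number of the three, and it alone lacks a methyl on this ring. Nothing at hand explains these differences.

Going by these compounds alone, the separate contributions of the fluorine and the methyl remain unresolved, as no pair here changes only one of them. Also open, on these data alone, is how this arm would read with a phenyl ring carrying an amine or a carboxylic acid.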